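A few compounds are considered here, and "the series" means these few. Any claim that something is new, unique, unknown or untested is made for them only; others in the source may bear on it.

Measured so far:
Compound 1, `CC(C)(O/N=C(\C(=O)N[C@@H]1C(=O)N(S(=O)(=O)O)[C@@H]1CN1CCCC1=O)c1csc(N)n1)C(=O)O`: in a physicochemical assay for metabolic stability, read by HPLC and mass spectrometry, in phosphate buffer, at 37 degrees C, at pH 7.4 (on this read-out higher numbers stand for a longer-lived compound and lower numbers for a shorter-lived compound), compound 1 gives > 1000 h, which is a limit of the assay and not a number.
Compound 2, `CC(C)(O/N=C(\C(=O)N[C@@H]1C(=O)N(S(=O)(=O)O)[C@@H]1CN1C[C@H](CN)OC1=O)c1csc(N)n1)C(=O)O`: in this assay compound 2 gives > 37 h, also a limit and not a number.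
Compound 3, `CC(C)(O/N=C(\C(=O)N[C@@H]1C(=O)N(S(=O)(=O)O)[C@@H]1Cn1cc(CO)nn1)c1csc(N)n1)C(=O)O`: not yet measured.

Compound 1 stands only at a limit in this assay, as the limit of > 1000 h in this assay, at which 1 of the 2 values shown sits, shows, and the other value shown is a limit as well, (the limit of > 37 h in this assay, at which 1 of the 2 values shown sits). Among the measured compounds shown here, the single measured step, a step that the two limits leave unreadable from compound 1 to compound 2, is therefore of no readable size. Compound 3 differs from compound 1 by 4-(hydroxymethyl)-1H-1,2,3-triazol-1-yl in place of 2-oxopyrrolidin-1-yl on a saturated chain carbon bound to a saturated ring carbon. For the measured compounds named here, no measured step speaks to this change in a readable way, so the two limits are all there is to lean on. Since both measured compounds sit at limits of long half-life, compound 3 is expected to be long-lived too, with an expected step of an at least 2.0-fold lower number from compound 1 to compound 3 (0.30 log units; that floor lies within the scatter). The estimate for compound 3 is 500 h, with a range from 40 h to 2000 h.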

Compound 3, half-life: > 37 h
Compound 3 was reported as a limit; the forecaster's own chance of this, stated with the estimate: 70%; the middle value is on the limit's open side.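

Among the compounds shown here, compound 1, compound 2 and compound 3 all stand only at limits in this assay, and no step among them can be read. The compounds shown leave open what the actual half-life of each one is, and whether swapping these groups changes it at all.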